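The compounds below may be only part of what the source reports. "The series", "measured", "known", "first", "only" and "open" are said of these compounds alone.

Going by the values given here, compound 2 `CC1(c2ccc(N)cc2)CC(=O)NC1=O` is one of two compounds measured in an assay on isolated protein for inhibition of Aromatase (Homo sapiens) (a higher number here means a weaker inhibitor, a lower number a stronger inhibitor), where compound 2 gives 12500 nM. Among the compounds with values here, the only other number belongs to compound 1 `CN1C(=O)CC(C)(c2ccc(N)cc2)C1=O`, which in this assay gives 15700 nM; the step of a 1.3-fold lower number from compound 1 to compound 2 (0.10 log units; within the scatter) separates the two, so compound 2 stands alongside compound 1 rather than apart from it. Compound 3 `Nc1ccc(C2CC(=O)NC2=O)cc1` differs from compound 2 by hydrogen in place of methyl on a saturated ring carbon, on a saturated ring carbon of a five-membered non-aromatic ring with 1 nitrogen, two ring bonds from the ring nitrogen. Within the data shown here, the one measured step, from compound 1 to compound 2, removed a methyl at a different place, the amide-type ring nitrogen, and was within the scatter; no step at the saturated ring carbon has been measured. On that basis the step of no change at the digits printed from compound 2 to compound 3 (within the scatter) is expected to stay within the scatter. Compound 3 is therefore estimated at 12500 nM in this assay, within a range from 5000 nM to 32000 nM.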

Compound 3, half-maximal inhibitory concentration: 20000 nM
Compound 3: middle estimate off by 1.6-fold (0.20 log units), on the low side; measured number inside the range.
By their numbers in this assay, from the lowest: compounds 2, 1 and 3 (each within the scatter of the next).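

At the saturated ring carbon, two ring bonds from the ring nitrogen, a measured step now exists: in this assay hydrogen in place of methyl gives little change (a 1.6-fold higher number from compound 2 to compound 3 (0.20 log units; within the scatter)). The earlier step at the amide-type ring nitrogen was also within the scatter (a 1.3-fold lower number from compound 1 to compound 2 (0.10 log units; within the scatter)), so among these three compounds, removing the methyl at either place leaves the number within the scatter of its neighbour. No measured evidence bears on this result.

On these data alone, it remains open whether a larger group at the saturated ring carbon, such as an ethyl or a longer chain, would move the number beyond the scatter. Equally open, as far as these compounds go, is what a nitrile or a carboxylic acid in place of the amine on the shared core would do.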